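A few compounds are considered here, and "the series" means these few. Any claim that something is new, unique, unknown or untested is made for them only; others in the source may bear on it.

Measured so far in an assay on HEK293 cells for inhibition of N-acylethanolamine-hydrolyzing acid amidase (Rattus norvegicus), read by LC-MS, with a stated time of 30 min; a higher number here means a weaker inhibitor, a lower number a stronger inhibitor:
compound 1 `O=C(CCCCCc1ccc(I)cc1)N1CCOC1=O` gives > 20000 nM
compound 2 `CSc1ccc(CCCCCC(=O)N2CCOC2=O)cc1` gives > 20000 nM
compound 3 `COc1ccc(CCCCCC(=O)N2CCOC2=O)cc1` gives > 20000 nM

The value of compound 1 is a limit of this assay and not a number. The value of compound 2 is likewise a limit. The value of compound 3 is likewise a limit, so compound 3 stands at the edge of what this assay resolves, together with the other two members of the series (the limit of > 20000 nM in this assay, at which 3 of the 3 values shown sit). The three substituent changes among them, a step that the two limits leave unreadable from compound 1 to compound 2, a step that the two limits leave unreadable from compound 1 to compound 3 and a step that the two limits leave unreadable from compound 2 to compound 3, therefore give no readable size in either direction.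

The next compound is compound 4 `NC(=O)c1ccc(CCCCCC(=O)N2CCOC2=O)cc1`, reached from compound 3 by carbamoyl in place of methoxy on an aromatic carbon. Within the data shown here, none of the measured steps bears on this change in a readable way; the series so far only shows that varying the group on this aromatic carbon has not brought any compound below the limit. For compound 4 the step of a number no higher from compound 3 to compound 4 (the limit leaves the size open) is therefore expected to stay within the scatter. Compound 4 is estimated at 20000 nM, with a range from 5000 nM to 80000 nM in this assay, and the result is most likely to be reported as a limit again.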

Compound 4, half-maximal inhibitory concentration: > 20000 nM
Compound 4: no number, only a limit (the forecaster's own chance of this, stated with the estimate: 70%); the middle value sits exactly at the limit.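

In this assay compound 4 gives > 20000 nM, a limit and not a number. No step among compound 1, compound 2, compound 3 and compound 4 can be read: the limit of > 20000 nM in this assay, at which 4 of the 4 values shown sit.

The compounds shown leave open how far any of the four lies beyond this limit, and whether any group on this aromatic carbon gives a measurable value.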